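Cyclic sulfonylurea series: nitrobenzamide replaced by ethyl carbamate

The source may report more compounds than this note shows. Statements on the series, on what has been measured and on what is new or still open speak of the compounds shown alone.

Measured so far:
compound 1 `Cc1cc(S(=O)(=O)N2C(=O)N[C@@H](c3ccccc3)C2C)ccc1NC(=O)c1ccc([N+](=O)[O-])cc1` — > 10000 nM
compound 2 `CC1[C@H](c2ccccc2)NC(=O)N1S(=O)(=O)c1ccc(NC(=O)c2ccc([N+](=O)[O-])cc2)c(Cl)c1` — > 10000 nM

In a functional assay on HCT-116 cells (Homo sapiens) for cytotoxicity, read by MTT assay (on this read-out lower numbers stand for stronger inhibition and higher numbers for weaker inhibition), compound 1 gives > 10000 nM, a limit of the assay rather than a number. Compound 2 gives > 10000 nM in this assay, likewise a limit. Within the data shown here, the only measured step, a step that the two limits leave unreadable from compound 1 to compound 2, chloro in place of methyl on an aromatic carbon, therefore has no readable size. Compound 1 thus stands at the limit of > 10000 nM in this assay, at which 2 of the 2 values shown sit.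

Compound 3 `CCOC(=O)Nc1ccc(S(=O)(=O)N2C(=O)N[C@@H](c3ccccc3)C2C)cc1C` differs from compound 1 in that (ethoxy in place of 4-nitrophenyl on a carbonyl carbon). Among the measured compounds shown here, no measured step touches the carbonyl substituent, and the one step that exists is unreadable, so nothing here points to a gain or loss in this assay for this change. The working expectation is that compound 3 will again sit at the limit in this assay. Compound 3 is estimated at 15000 nM, from 4000 nM to 60000 nM. This estimate means an expected step that the limit leaves unreadable from compound 1 to compound 3, which a limit on both sides would leave unreadable.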

Compound 3, half-maximal inhibitory concentration: 5500 nM
For compound 3 the middle estimate is 2.7-fold (0.44 log units) above the measured one; low and high end bracket the measured number.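

In this assay the change of ethoxy in place of 4-nitrophenyl on a carbonyl carbon reads as an at least 1.8-fold lower number from compound 1 to compound 3 (0.25 log units; that floor lies within the scatter), so a gain beyond the scatter cannot be claimed from this floor alone. Even so, compound 3 gives a real number, 5500 nM, which shows that the 4-nitrophenyl group is not needed for a measurable value on the core of compound 1. The other two compounds remain at the limit: the limit of > 10000 nM in this assay, at which 2 of the 3 values shown sit.

As far as these compounds go, the true size of the step stays open, as does whether a longer chain such as butoxy, or an amine on the same carbonyl carbon, would move the value further. Also open, from the compounds shown here alone, is whether chloro in place of methyl on an aromatic carbon would change the value of compound 3.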